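A few compounds are considered here, and "the series" means these few. Any claim that something is new, unique, unknown or untested is made for them only; others in the source may bear on it.

Measured compounds and their values:

Compound 1, `C=Cc1c(C)nn(CC(C)CN2CCN(c3ccc(C)cc3)CC2)c(=O)c1N`: 17%
Compound 2, `Cc1c(C#N)c(-c2ccccc2)nn1CCCN1CCN(c2ccc(F)cc2)CC1`: 9%
Compound 3, `COc1cccc(N2CCN(CCCn3nc(-c4ccccc4)c(C#N)c3C)CC2)c1`: 0%

All three were tested in a functional assay on the whole organism (Abdomen, strain Swiss) for inhibition, with Mus musculus as the target, with stated times of 30 min, 10 min and 5 min, at a dose of 10 mg/kg by the oral route; on this read-out lower numbers stand for a weaker effect and higher numbers for a stronger effect at the one dose given. Compound 3 stands lowest of the three numbers; its nearest neighbour is compound 2, and the step of a number 9 percentage points lower from compound 2 to compound 3 (within the scatter) lies within the usual scatter, so the two cannot be ranked. Compound 1 lies furthest away, and that gap is beyond the scatter.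

Compound 4, `Cc1ccc(N2CCN(CCCn3nc(-c4ccccc4)c(C#N)c3C)CC2)cc1`, is not yet measured. It differs from compound 3 in one place: 4-methylphenyl in place of 3-methoxyphenyl on an amine nitrogen in a ring. Among the measured compounds shown here, the only measured step that bears on this kind of change is the one from compound 2 to compound 3, where a different group on the same ring nitrogen was exchanged and the outcome stayed within the scatter. Compound 1 carries a 4-methylphenyl too, but on a different core, so it gives little guidance. A step of no size beyond the scatter is therefore expected, and compound 4 is estimated at 8%, in the range 0% to 22%. The expected step is a number 8 percentage points higher from compound 3 to compound 4 (within the scatter).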

Compound 4, a percentage reported as inhibition, in the whole organism at one dose (the size of the read-out at that dose, not a potency): 0%
Compound 4: the middle estimate sits 8 percentage points above what was measured, and the stated range covers the measured number.
By their numbers in this assay, from the lowest: compounds 3, 4, 2 and 1 (each within the scatter of the next, the first and the last beyond it).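

In this assay, 4-methylphenyl in place of 3-methoxyphenyl on the amine nitrogen in a ring gives two compounds that cannot be told apart (no change at the digits printed from compound 3 to compound 4 (within the scatter)). Methyl in place of fluoro on an aromatic carbon gives the same picture (a number 9 percentage points lower from compound 2 to compound 4 (within the scatter)), so on the shared core, a phenyl group bearing methoxy, fluoro or methyl shows no separation at this single oral dose. Nothing available here explains this result.

From the compounds shown here alone, all three numbers on the shared core sit low on the scale, so it stays open whether any group at this position can give a clearly stronger effect. Going by these compounds, whether an amine or a carboxylic acid on that phenyl ring, or a longer chain leading to the six-membered ring, would separate from these compounds also remains open.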